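The source may report more compounds than this note shows. Statements on the series, on what has been measured and on what is new or still open speak of the compounds shown alone.

Measured so far in an assay on COS-7 cells for inhibition of patatin-like phospholipase domain-containing protein 2 (Mus musculus), tested at 200 uM; on this read-out lower numbers stand for less inhibition and higher numbers for more inhibition at the one concentration tested (going by the name of the read-out):

Compound 1 `CCOC(=O)c1ccc(-c2ccc(OCC)cc2)[nH]1` gives 44%.
Compound 2 `CCOC(=O)c1cccc(-c2ccc(OCC)c([N+](=O)[O-])c2)c1` gives 44%.
Compound 3 `CCOc1ccc(-c2cccc(S(=O)(=O)NC)c2)cc1` gives 47%.

The three numbers in this assay sit close together. Compound 3 carries the uppermost number of the three, but its gap to compound 1 and its gap to compound 2 both lie within the usual scatter, so the three compounds cannot be told apart on these data. From the compounds shown here alone, no single-point change between two measured compounds is available, so the size of a step from a substituent swap on the outer ring is unknown here.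

Compound 4 `CCOc1ccc(-c2cccc([N+](=O)[O-])c2)cc1` is the next entry for this assay. Against compound 3 the change is nitro in place of methylsulfamoyl on an aromatic carbon. Within the data shown here, nothing among the measured compounds separates from the rest, and compound 2, which also carries a nitro, gives 44%, so the expectation for this step is none beyond the scatter.

The expected step in this assay is a number 3 percentage points lower from compound 3 to compound 4 (within the scatter). Compound 4 is therefore estimated at 44%, with a likely range from 30% to 58%.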

Compound 4, a percentage reported as inhibition, at one concentration (the size of the read-out at that concentration, not a potency): 35%
Beside the measured number, compound 4's estimate is 9 percentage points above it; the measured number falls inside the stated range.
By their numbers in this assay, from the lowest: compounds 4, 1, 2 and 3 (each within the scatter of the next, the first and the last beyond it).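

In this assay, a number 12 percentage points lower from compound 3 to compound 4 (beyond the scatter) gives the series its first single-place step, and it shows that the group on this aromatic carbon can move the read-out beyond the scatter. The methylsulfamoyl group differs from nitro in heavy atoms and in carrying a hydrogen-bond donor, and this one step cannot separate those differences. No measurement on hand bears on what lies behind the step.

From the compounds shown here alone, it remains open whether a carboxylic acid, an amine or a nitrile on this carbon would read like compound 3 or like compound 4, and whether a longer chain on the sulfonamide nitrogen would change the read-out. Going by these compounds, whether the same swap gives a similar step on another core also remains open.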